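Replacing thiophen-3-yl with ethynyl on an inactive compound

The source may hold more compounds than are shown below. What is called first, only, known or untested is meant among the compounds shown, and "the series" means these compounds.

In a functional assay on HCT-116 cells (Homo sapiens), read by MTT assay, with a stated time of 72 h (a higher number here means a weaker inhibitor, a lower number a stronger inhibitor), compound 2 `CN(C)c1ncnc2c1c(-c1ccsc1)cn2[C@@H]1O[C@H](CO)[C@@H](O)[C@H]1O` gives > 20000 nM, which is a limit of the assay and not a number. Compound 3 `C#Cc1cn([C@@H]2O[C@H](CO)[C@@H](O)[C@H]2O)c2ncnc(N(C)C)c12` differs from it in one place: ethynyl in place of thiophen-3-yl on an aromatic carbon, with ethynyl in place of thiophen-3-yl on an aromatic carbon. Compound 1 `C#Cc1cn([C@@H]2O[C@H](CO)[C@@H](O)[C@H]2O)c2ncnc(SC)c12` also bears ethynyl, though it differs from compound 3 elsewhere, and compound 1 gives 90 nM. On that basis, a large move towards stronger inhibition is expected in this assay. The estimated change is an at least 20-fold lower number from compound 2 to compound 3 (1.30 log units; beyond the scatter). Compound 3 is expected to give 1000 nM, within an estimated range of 100 nM to 15000 nM.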

Compound 3, half-maximal inhibitory concentration: 290 nM
For compound 3 the middle estimate is 3.4-fold (0.54 log units) above the measured one; low and high end bracket the measured number.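

With dimethylamino kept on the shared core, ethynyl in place of thiophen-3-yl on this aromatic carbon gives an at least 68-fold lower number from compound 2 to compound 3 (1.83 log units; beyond the scatter) in this assay. The compound 2 end of that step is a limit of the assay and not a number: the limit of > 20000 nM in this assay, at which 1 of the 3 values shown sits. With ethynyl held fixed, dimethylamino in place of methylsulfanyl gives a 3.2-fold higher number from compound 1 to compound 3 (0.51 log units; beyond the scatter), a modest step beside the first.

Within the data shown here, only two groups on this carbon can be compared with dimethylamino kept. As far as these compounds go, whether the triple bond matters remains open, and an ethyl chain or a phenyl ring at this place would address it.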